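The source may report more compounds than this note shows. Statements on the series, on what has been measured and on what is new or still open speak of the compounds shown alone.

Measured so far:

Compound 1, `CNC(=O)CCc1ccncc1-c1ccc2ccccc2c1`, in a functional assay on MCF7 cells (Homo sapiens) for inhibition, read by sulforhodamine B assay, with a stated time of 72 h (a lower number here means a stronger inhibitor of growth, a higher number a weaker inhibitor of growth), gives > 10000 nM, which is a limit of the assay and not a number.
Compound 2, `O=C(O)CCc1ccncc1-c1ccc2ccccc2c1`, in this assay gives > 10000 nM, again a limit of the assay.
Compound 3, `CNC(=O)/C=C/c1ccncc1-c1ccc2[nH]ccc2c1`, in this assay gives > 10000 nM, also a limit of the assay.

Compound 1 and compound 2 share one core and differ in a single place: hydroxy in place of methylamino on a carbonyl carbon. The step that the two limits leave unreadable from compound 1 to compound 2 cannot be read, because both values sit at the limit of > 10000 nM in this assay, at which 3 of the 3 values shown sit.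

Compound 3 carries a different core, and the difference between the two cores is not broken down here. The unmeasured compound 4, `O=C(O)/C=C/c1ccncc1-c1ccc2[nH]ccc2c1`, stands to compound 3 as compound 2 stands to compound 1: hydroxy in place of methylamino on a carbonyl carbon. The place is not identical, though: in compound 1 the carbonyl carbon's other neighbour is a saturated chain carbon, while in compound 3 it is a double-bonded chain carbon, so this is the same kind of change rather than the same change.

The step from compound 3 to compound 4 is expected to be a step that the limit leaves unreadable from compound 3 to compound 4, and this rests on compound 1 and compound 2 both standing at the limit of > 10000 nM in this assay, at which 3 of the 3 values shown sit, and on compound 3 giving > 10000 nM in this assay. Compound 4 is therefore estimated to give about 20000 nM in this assay, most likely reported only as a limit, with an expected range from 8000 nM to 60000 nM.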

Compound 4, concentration for 50% growth inhibition: > 10000 nM
Compound 4 ended at the assay's limit (the forecaster's own chance of this, stated with the estimate: 85%); the middle value is on the limit's open side.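

The step from compound 3 to compound 4 cannot be read, because the values of both compounds are limits of this assay and not numbers: the limit of > 10000 nM in this assay, at which 4 of the 4 values shown sit. The compounds shown leave open how strongly any of them inhibits growth, and whether hydroxy in place of methylamino on a carbonyl carbon makes any difference to that inhibition.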